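Swapping the 4-aminocyclohexyl group of compound 2

The source may report more compounds than this note shows. Statements on the series, on what has been measured and on what is new or still open speak of the compounds shown alone.

In an ADME assay on microsomes from liver (Rattus norvegicus) for metabolic stability, read by LC-MS, tested at 1 uM (a higher number here means faster removal of the compound, a lower number slower removal), compound 2 (`N[C@H]1CC[C@@H](Oc2ccc([C@H]3CC[C@]4(CC3)OOC3(O4)C4CC5CC(C4)CC3C5)cc2)CC1`) gives only a limit (< 7 mL.min-1.g-1). Compound 1 (`NCCCOc1ccc([C@H]2CC[C@]3(CC2)OOC2(O3)C3CC4CC(C3)CC2C4)cc1`) also gives only a limit (< 7 mL.min-1.g-1). For the measured compounds named here, both sit at one boundary (the limit of < 7 mL.min-1.g-1 in this assay, at which 2 of the 2 values shown sit), so the single measured step (a step that the two limits leave unreadable from compound 1 to compound 2) has no readable size. Compound 3 (`CC1(C)CC(O)(COc2ccc([C@H]3CC[C@]4(CC3)OOC3(O4)C4CC5CC(C4)CC3C5)cc2)CC(C)(C)N1`) carries one change ((4-hydroxy-2,2,6,6-tetramethylpiperidin-4-yl)methyl in place of 4-aminocyclohexyl on an oxygen on an aromatic ring). With no measured size to build on, no shift beyond the scatter is expected in this assay, and the expected step is small (a step that the limit leaves unreadable from compound 2 to compound 3). The estimate for compound 3 is 6 mL.min-1.g-1, with an expected range from 3 mL.min-1.g-1 to 18 mL.min-1.g-1.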

Compound 3, intrinsic clearance in microsomes: < 7 mL.min-1.g-1
Compound 3 was reported as a limit; the forecaster's own chance of this, stated with the estimate: 55%; the middle value does not contradict the limit.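

No step among compound 1, compound 2 and compound 3 can be read in this assay, because all three values are limits at one boundary: the limit of < 7 mL.min-1.g-1 in this assay, at which 3 of the 3 values shown sit.

On these data alone, whether these side chains differ in clearance at all remains open.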